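The source may hold more compounds than are shown below. What is called first, only, known or untested is meant among the compounds shown, and "the series" means these compounds.

In a functional assay on ECa-109 cells for inhibition, with ECa-109 cell line (Homo sapiens) as the target, read by sulforhodamine B assay (a lower number here means a stronger inhibitor, a higher number a weaker inhibitor), compound 1 `O=C1C(Nc2ccc(I)cc2)=CC(=O)c2c1nc1n2[C@H]2OC[C@@H](O)[C@H]2OC1` gives 2530 nM. Compound 2 `CCc1ccc(NC2=CC(=O)c3c(nc4n3[C@H]3OC[C@@H](O)[C@H]3OC4)C2=O)cc1` gives > 4000 nM, which is a limit of the assay and not a number. Compound 3 `COc1ccccc1NC1=CC(=O)c2c(nc3n2[C@H]2OC[C@@H](O)[C@H]2OC3)C1=O` differs from compound 2 as follows: 2-methoxyphenyl in place of 4-ethylphenyl on an amine nitrogen. Going by the values given here, the only measured step, an at least 1.5-fold higher number from compound 1 to compound 2 (0.19 log units; that floor lies within the scatter), is a different exchange and its floor lies within the scatter, so no step beyond the scatter, in either direction, is expected in this assay. The expected change is an at least 1.1-fold lower number from compound 2 to compound 3 (0.05 log units; that floor lies within the scatter). Compound 3 is estimated at 3500 nM, within a range from 1300 nM to 7000 nM.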

Compound 3, half-maximal inhibitory concentration: > 4000 nM
Compound 3: no number, only a limit; the forecaster's own chance of this, stated with the estimate: 45%; middle value at least 1.1-fold (0.05 log units) from the limit.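

In this assay compound 3 gives > 4000 nM, which is a limit of the assay and not a number. Going by these compounds alone, the exchange of 4-iodophenyl for 2-methoxyphenyl on the amine nitrogen gives an at least 1.5-fold higher number from compound 1 to compound 3 (0.19 log units; that floor lies within the scatter), so a second replacement of the 4-iodophenyl also yields no step confirmed beyond the scatter. The step between compound 2 and compound 3 cannot be read because both stop at the same limit: the limit of > 4000 nM in this assay, at which 2 of the 3 values shown sit.

The compounds shown leave open how a smaller group on this amine nitrogen, such as methyl, would read. They also leave open whether a 4-carboxyphenyl group there would give a number rather than a limit.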